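A few compounds are considered here, and "the series" means these few. Any claim that something is new, unique, unknown or untested is made for them only; others in the source may bear on it.

Working notes on the series in an ADME assay on HEL cells (Homo sapiens) for cytotoxicity, with a stated time of 3 days; a higher number here means that more compound is tolerated, a lower number that less compound is tolerated.

Compound 1 `Cc1cc(-c2ccsc2)cn2c(CSCc3ccccc3)cnc12` gives 9.4 ug/mL. Compound 3 `Cc1cc(N2CCCC2)c2ncc(CSCc3ccccc3)n2c1`, which carries the same chain on the sulfur but a different substituent on the core, gives 52 ug/mL. For compound 2 `Cc1cc(N2CCCC2)c2ncc(CSCCc3ccccc3)n2c1` only a limit is recorded, > 100 ug/mL; this is the same limit as the limit of > 100 ug/mL in this assay, at which 1 of the 3 values shown sits. Compound 2 therefore stands at the upper edge of the numbers shown and has no exact value.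

Within the data shown here, the one measured step, an at least 1.9-fold lower number from compound 2 to compound 3 (0.28 log units; that floor lies within the scatter), concerns the chain on the sulfur and not the substituent on the core.

Compound 4 `Cc1cc(-n2ccc3cccnc32)c2ncc(CSCCc3ccccc3)n2c1` keeps the chain of compound 2 and differs only in a group of 9 heavy atoms (7 carbon, 2 nitrogen; one five-membered aromatic ring with 1 hetero atom, one six-membered aromatic ring with 1 hetero atom) in place of a group of 5 heavy atoms (4 carbon, 1 nitrogen; one five-membered non-aromatic ring with 1 hetero atom), on an aromatic carbon. No measured step in this set changes that position, so the direction of its effect is not known from the steps shown; the values of compound 1 and compound 3 show that a change at the core substituent can move the number, but the size for this particular exchange is open. Compound 4 is expected to give 60 ug/mL, with a range from 20 ug/mL to 100 ug/mL, a step of an at least 1.6-fold lower number from compound 2 to compound 4 (0.22 log units; that floor lies within the scatter) that is expected to be modest in either direction.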

Compound 4, half-maximal cytotoxic concentration: > 100 ug/mL
Compound 4 ended at the assay's limit; the forecaster's own chance of this, stated with the estimate: 35%; at least 1.6-fold (0.22 log units) between middle value and limit.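

Compound 2 and compound 4 both end at a limit rather than a number, so no step between them can be read: the limit of > 100 ug/mL in this assay, at which 2 of the 4 values shown sit.

The compounds shown leave open whether exchanging the pyrrolidin-1-yl group for the group of 9 heavy atoms moves the number at all.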